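The source may hold more compounds than are shown below. What is called first, only, known or untested is meant among the compounds shown, and "the series" means these compounds.

Measured so far: compound 1 `O[C@@H]1[C@@H](O)[C@H](Oc2ccc3ccccc3c2)OC[C@H]1O` with 243 uM; 50 uM (2 entries) in an ADME assay on CCD-1095SK cells (Homo sapiens) for antiproliferative activity, read by crystal violet staining, with a stated time of 96 h; a lower number here means that less compound is needed, a higher number that more compound is needed for the effect; compound 2 `O[C@H]1[C@H](Oc2ccc3ccccc3c2)OCC[C@@H]1O` with 285 uM.

Among the measured compounds shown here, compound 2 has only this one number in this assay, and on that number it stands at the high end of what has been measured. Compound 1 gives two readings that lie well apart, (the several entries of compound 1 in this assay, 243 uM; 50 uM (2 entries)), so the spread of the two entries is itself a caution on how much any single value here can carry.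

The step goes from compound 2 to compound 3 `O[C@@H]1[C@@H](O)[C@H](Oc2ccc3ccccc3c2)OC[C@@H]1O`. The change is hydroxy in place of hydrogen on a saturated ring carbon.

For the measured compounds named here, no step between measured compounds of this kind is available, so the size of the step in this assay has to be expected rather than read off. Given that compound 2 gives 285 uM and that compound 1, which carries the hydroxy group, gives 243 uM; 50 uM (2 entries), the step from compound 2 to compound 3 is expected to be small, if anything toward a lower value, and quite possibly none beyond the scatter. On that basis compound 3 is estimated to give 200 uM in this assay, within 60 uM to 500 uM, an expected step of a 1.4-fold lower number from compound 2 to compound 3 (0.15 log units; within the scatter).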

Compound 3, concentration for half-maximal effect: 48 uM
The estimate for compound 3 lay 4.2-fold (0.62 log units) above the measured number, and the stated range ends above it.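

In this assay, among the compounds shown here, hydroxy in place of hydrogen on this saturated ring carbon gives a 5.9-fold lower number from compound 2 to compound 3 (0.77 log units; beyond the scatter), so this position, two ring bonds from the ring oxygen, now has a step that lies beyond the scatter, which the earlier compounds could not show. Compound 3 can also be set directly against compound 1: the fact that compounds 1 and 3 differ only in the configuration as drawn. Compound 3 gives 48 uM and compound 1 gives 243 uM; 50 uM (2 entries), so the number for compound 3 lies close to one entry of compound 1 and well apart from the other, and these values do not settle whether the configuration as drawn matters.

On these data alone, the step rests on one number each for compound 2 and compound 3, and given the spread seen for compound 1, it remains open whether its size would hold across repeated readings. The compounds shown also leave open whether a methoxy group or an amine on the same ring carbon would give a step like the one seen with hydroxy.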